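The source may report more compounds than this note shows. Statements on the series, on what has been measured and on what is new or still open speak of the compounds shown alone.

Measured compounds, all in an ADME assay on isolated protein for inhibition of Dipeptidyl peptidase 9 (Homo sapiens), with stated times of 15 min, 60 s and 20 min; a lower number here means a stronger inhibitor, a higher number a weaker inhibitor:

- compound 1, `CC#CCn1c(N2CCC[C@@H](N)C2)nc2c1c(=O)n(Cc1cc(Br)ccc1C(=O)O)c(=O)n2C`: > 100000 nM (a limit of the assay)
- compound 2, `CC#CCn1c(N2CCC[C@@H](N)C2)nc2c1c(=O)n(Cc1cc(Cl)ccc1C(=O)O)c(=O)n2C`: > 100000 nM (a limit of the assay)
- compound 3, `CC#CCn1c(N2CCC[C@@H](N)C2)nc2c1c(=O)n(Cc1ccc(Cl)cc1C(=O)OC)c(=O)n2C`: > 100000 nM (a limit of the assay)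

Compound 3 stands at a limit of this assay, as do the two other measured compounds; no numerical value for it is known. The steps among the measured compounds, a step that the two limits leave unreadable from compound 1 to compound 2, a step that the two limits leave unreadable from compound 1 to compound 3 and a step that the two limits leave unreadable from compound 2 to compound 3, cannot be read in size or direction, because every value shown sits at the limit of > 100000 nM in this assay, at which 3 of the 3 values shown sit.

Compound 4, `CC#CCn1c(N2CCC[C@@H](N)C2)nc2c1c(=O)n(Cc1ccc(F)cc1C(=O)O)c(=O)n2C`, is not yet measured. It differs from compound 3 by 2-carboxy-4-fluorophenyl in place of 4-chloro-2-(methoxycarbonyl)phenyl on a saturated chain carbon bound to an aromatic nitrogen. The closest measured pair for this kind of change is compound 2 against compound 3, where a free acid and an ester are both at the limit, so nothing is known about the size of an acid-for-ester exchange here. The halogen exchanges in the series are likewise unreadable.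

With every measured value at the limit, no step beyond the scatter can be inferred from the measured compounds. The step is expected to be a step that the limit leaves unreadable from compound 3 to compound 4, that is, no readable change. Compound 4 is therefore estimated to give 150000 nM in this assay, in the range 40000 nM to 600000 nM, most likely reported again only as a limit.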

Compound 4, half-maximal inhibitory concentration: > 100000 nM
Compound 4: only a limit was reported; the forecaster's own chance of this, stated with the estimate: 85%; the middle value is on the limit's open side.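

In this assay compound 4 gives > 100000 nM, a limit of the assay. No step between compound 4 and compound 1, compound 2 or compound 3 can be read in size or direction, because all four compounds share one limit: the limit of > 100000 nM in this assay, at which 4 of the 4 values shown sit.

The compounds shown leave open how strongly each inhibits and whether exchanging the halogen, or the free acid for the ester, changes that.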